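One Chloro Group Added to Compound 2

The source may hold more compounds than are shown below. What is called first, only, known or untested is meant among the compounds shown, and "the series" means these compounds.

Measured so far in an ADME assay on microsomes from liver (Rattus norvegicus) for metabolic stability, with a stated time of 10 min, tested at 0.5 uM; a lower number here means that less of the compound is left, a higher number that more of the compound is left:
Compound 1 `CC(C)COc1ncc(-c2cn(C)c3cc(C(=O)NS(C)(=O)=O)ccc23)cc1Cl` gives 66%
Compound 2 `CC(C)COc1ccc(-c2cn(C)c3cc(C(=O)NS(C)(=O)=O)c(F)cc23)cn1` gives 98%

Compound 2 stands at 98% and is the higher of the two, with a gap to compound 1 that lies beyond the usual scatter of this kind of measurement. Nearly all of compound 2 is still present at the end of the test.

Compound 3 `CC(C)COc1ncc(-c2cn(C)c3cc(C(=O)NS(C)(=O)=O)c(F)cc23)cc1Cl` has not been measured yet. It arises from compound 2 through a single change (chloro in place of hydrogen on an aromatic carbon): chloro in place of hydrogen on an aromatic carbon, ortho to an isobutoxy group.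

Going by the values given here, no pair of measured compounds isolates this change, so the forecast rests on thin evidence. Compound 1 also carries this chloro group and gives the lower value (66%), but it differs from compound 2 in a second place as well. In this assay the expected step of a number 23 percentage points lower from compound 2 to compound 3 (beyond the scatter) is therefore a fall beyond the scatter, though a smaller one is possible. The expected value for compound 3 is 75% (estimated range 55% to 93%).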

Compound 3, percent of the compound remaining: 85%
Compound 3: middle estimate off by 10 percentage points, on the low side; the range from low to high includes it.
By their numbers in this assay, from the lowest: compound 1; then compound 3; then compound 2.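

In this assay, the chloro group on an aromatic carbon, ortho to an isobutoxy group, can now be read on its own. Compound 3 differs from compound 2 in this one place: the change gives a number 13 percentage points lower from compound 2 to compound 3 (beyond the scatter) and so has a real but modest cost at this position. Compound 3 also isolates a second single change, since adding a fluoro group gives a number 19 percentage points higher from compound 1 to compound 3 (beyond the scatter) and thus moves the amount of compound left in the opposite direction. With the chloro group present, the fluoro group still goes with more compound remaining, so neither change has to be read through the other, yet the data shown give no measured explanation for either step.

As far as these compounds go, whether a methyl group or a nitrile on the same aromatic carbon would leave more or less of the compound than chloro remains open. Also open, from the compounds shown here alone, is whether the two steps would keep their size and direction if a longer chain took the place of the isobutoxy group.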